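This account rests on a few compounds, and the source may have more. Where it says the series, first, only, none or still open, it means among the compounds named here.

In a functional assay for inhibition, with Rattus norvegicus as the target (a lower number here means a stronger inhibitor, a higher number a weaker inhibitor), compound 1 (`CC(C)(C)/N=c1\c(O)c(O)\c1=N/Cc1cccnc1`) gives 2600 nM and compound 2 (`CC(C)(C)/N=c1\c(O)c(O)\c1=N/Cc1ccncc1`) gives 3000 nM, so these two values lie within the usual scatter of each other. Compound 3 (`CC(C)(C)/N=c1\c(O)c(O)\c1=N/Cc1ccccn1`) differs from compound 2 as follows: pyridin-2-yl in place of pyridin-4-yl on a saturated chain carbon bound to a double-bonded nitrogen. Going by the values given here, the one measured step that bears on this change is the swap of pyridin-3-yl for pyridin-4-yl, a 1.2-fold higher number from compound 1 to compound 2 (0.06 log units; within the scatter), and it stays within the scatter. Among the compounds with values here, no measured compound yet carries pyridin-2-yl, so no step beyond the scatter is expected in this assay, though with wide uncertainty. The estimated step is no change at the digits printed from compound 2 to compound 3 (within the scatter). For compound 3 the expected value is 3000 nM, with an estimated range of 1000 nM to 9000 nM.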

Compound 3, half-maximal inhibitory concentration: 11500 nM
The estimate for compound 3 lay 3.8-fold (0.58 log units) below the measured number, outside the stated range (above it).
By their numbers in this assay, from the lowest: compounds 1 and 2 (each within the scatter of the next); then compound 3.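

In this assay, pyridin-2-yl in place of pyridin-4-yl brings a 3.8-fold higher number from compound 2 to compound 3 (0.58 log units; beyond the scatter) and, in place of pyridin-3-yl, brings a 4.4-fold higher number from compound 1 to compound 3 (0.65 log units; beyond the scatter) as well. This place on the saturated chain carbon bound to a double-bonded nitrogen therefore distinguishes between pyridine attachments, although the earlier swap of pyridin-3-yl for pyridin-4-yl stayed within the scatter, and compound 3 is the weakest of the three. No measurement offered here explains this loss. Still open, going by these compounds, is how a plain phenyl ring or a carboxylic acid in this place would compare with the pyridines.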